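Methoxy added to the phenyl thiosemicarbazone of compound 3

The compounds below may be only part of what the source reports. "The series", "measured", "known", "first", "only" and "open" are said of these compounds alone.

Three quinoline thiosemicarbazones have been tested in a functional assay on HeLa cells (Homo sapiens) for antiproliferative activity, read by sulforhodamine B assay, with a stated time of 72 h; a higher number here means a weaker inhibitor, a lower number a stronger inhibitor. Compound 1 `COc1ccc(C)cc1NC(=S)N/N=C/c1ccc2ccccc2n1` reaches only a limit of the assay, > 100000 nM. Compound 2 `Cc1cccc(NC(=S)N/N=C/c2ccc3ccccc3n2)c1` likewise stops at a limit, > 100000 nM. Going by the values given here, compound 3 `S=C(N/N=C/c1ccc2ccccc2n1)Nc1ccccc1` is the one compound with a number, and in this assay compound 3 gives 27400 nM.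

The cores of compound 2 and compound 3 differ by hydrogen in place of methyl on an aromatic carbon, and the step is an at least 3.6-fold lower number from compound 2 to compound 3 (0.56 log units; beyond the scatter). The change from compound 2 to compound 1 is methoxy in place of hydrogen on an aromatic carbon, and its step is a step that the two limits leave unreadable from compound 2 to compound 1, since both values sit at the limit of > 100000 nM in this assay, at which 2 of the 3 values shown sit.

Compound 4 `COc1ccc(NC(=S)N/N=C/c2ccc3ccccc3n2)cc1` has not been measured. It differs from compound 3 by methoxy in place of hydrogen on an aromatic carbon. Among the compounds with values here, this is the same kind of change as the one from compound 2 to compound 1, but not the same: there the methoxy entered ortho to a large group and para to a methyl group, here it enters para to a large group.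

The earlier methoxy step gives no readable size, so the expectation for compound 4 rests mainly on the measured number of compound 3, 27400 nM, and is taken as roughly flat, a 1.3-fold higher number from compound 3 to compound 4 (0.11 log units; within the scatter), with wide uncertainty. Compound 4 is therefore estimated at 35000 nM, in a range from 9000 nM to 150000 nM, with a real chance that, like compound 1 and compound 2, it is reported only as a limit.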

Compound 4, half-maximal inhibitory concentration: 72600 nM
For compound 4 the middle estimate is 2.1-fold (0.32 log units) below the measured one, and the stated range covers the measured number.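

In this assay the methoxy change now has one readable size, a 2.6-fold higher number from compound 3 to compound 4 (0.42 log units; beyond the scatter), so on the phenyl group of compound 3 this change moves the number beyond the scatter, towards a weaker inhibitor. That size comes from a single pair, since the other methoxy step, on the core of compound 2, cannot be read and so offers no second size to set against it, which leaves it unshown whether the size carries from one core to another: the limit of > 100000 nM in this assay, at which 2 of the 4 values shown sit. The remaining new step, an at least 1.3-fold lower number from compound 2 to compound 4 (0.13 log units; that floor lies within the scatter), replaces 3-methylphenyl with 4-methoxyphenyl, and since its floor lies within the scatter, it does not place these two compounds in any order.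

The compounds shown carry only methyl and methoxy groups on the phenyl ring, so they leave open how an amine, a carboxylic acid or a longer chain such as ethoxy would behave there. They also leave open whether methoxy in the place it holds in compound 4 would give a similar step on a phenyl group that already carries another substituent.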